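Trifluoromethyl for pentyl on a cytotoxicity read-out

The compounds below may be only part of what the source reports. "The series", "measured", "known", "first", "only" and "open" are said of these compounds alone.

The compounds measured so far, with their values in an ADME assay on Vero cells (Chlorocebus sabaeus) for cytotoxicity; on this read-out higher numbers stand for weaker inhibition and lower numbers for stronger inhibition:

Compound 1 `CCCCCc1ccc(N2C(=O)c3cccnc3C2=O)cc1`: 18000 nM
Compound 2 `CC(C)(C)N1C(=O)c2nccnc2C1=O`: 32000 nM
Compound 3 `CC(C)(C)N1C(=O)c2cccnc2C1=O`: 33000 nM

All three numbers lie close together at the weak end of the range. Compound 1 gives the lowest of the three numbers in this assay, but its distance to compound 2 and to compound 3 is within the usual scatter of repeated measurements, so no ranking among them can be drawn from these values. Compound 2 and compound 3 share a tert-butyl substituent on the imide nitrogen, whereas compound 1 carries an aryl group bearing a pentyl chain; the data show no separation between the two kinds of substituent.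

Compound 4 `O=C1c2cccnc2C(=O)N1c1ccc(C(F)(F)F)cc1` has not yet been measured in this assay. It differs from compound 1 in one place:

trifluoromethyl in place of pentyl on an aromatic carbon

Within the data shown here, no step between measured compounds is available to calibrate this change. Given how tightly compound 1, compound 2 and compound 3 cluster, the expected step is none beyond the scatter, with at most a slight move toward a higher number; the estimated step is a 1.3-fold higher number from compound 1 to compound 4 (0.12 log units; within the scatter). Compound 4 is therefore expected to give about 24000 nM, within a range of 10000 nM to 60000 nM.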

Compound 4, half-maximal inhibitory concentration: 87000 nM
For compound 4 the middle estimate is 3.6-fold (0.56 log units) below the measured one; the measured number lies above the stated range.
By their numbers in this assay, from the lowest: compounds 1, 2 and 3 (each within the scatter of the next); then compound 4.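

In this assay, the step from pentyl to trifluoromethyl on the aromatic carbon para to a large group is a 4.8-fold higher number from compound 1 to compound 4 (0.68 log units; beyond the scatter) and so lies beyond the scatter, which shows that this read-out does respond to what this position carries. The earlier compounds shown here could not show this: their numbers sat within the scatter of one another and no pair among them differed in one place, whereas this pair isolates a single change on an otherwise shared core. Nothing in hand accounts for the size or direction of this step, and it rests on this one pair alone.

With only pentyl and trifluoromethyl seen at this position, the compounds shown leave open whether the higher number follows from the loss of the pentyl chain or from the arrival of the trifluoromethyl group, a question that a methyl group, a propyl chain or a plain hydrogen at the same carbon would help to settle. They also leave open how a longer chain, an amine or a carboxylic acid would behave there, and whether the same change would give a step of similar size on another core.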